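From Thiophen-2-yl to 4-Hydroxyphenyl on a Sulfonyl Sulfur

The compounds below may be only part of what the source reports. "The series", "measured", "known", "first", "only" and "open" are said of these compounds alone.

Compound 1 `O=S(=O)(Nc1ccc(-c2nc3ccccc3o2)cc1)c1cccs1` was tested in an assay on cells for inhibition of HSP60/HSP10 (Homo sapiens), with a stated time of 60 min (a lower number here means a stronger inhibitor, a higher number a weaker inhibitor), where compound 1 gives 63000 nM, the highest of the two numbers shown. Compound 2 `O=S(=O)(Nc1ccc(-c2nc3cc(NS(=O)(=O)c4ccccc4F)ccc3o2)cc1)c1ccccc1F` gives 57000 nM in this assay, a difference from compound 1 that lies within the scatter. Compound 3 `Cc1ccc(S(=O)(=O)Nc2ccc3oc(-c4ccccc4)nc3c2)cc1` reaches only the limit of this assay, > 100000 nM, and so yields no number. Compound 4 `O=S(=O)(Nc1ccc(-c2nc3ccccc3o2)cc1)c1ccc(O)cc1` has not yet been measured in this assay. It differs from compound 1 as follows: 4-hydroxyphenyl in place of thiophen-2-yl on a sulfonyl sulfur. Within the data shown here, no measured step of this kind is available, and a change beyond the scatter in either direction is not anticipated. The expected step is a 1.1-fold lower number from compound 1 to compound 4 (0.06 log units; within the scatter). Compound 4 is therefore estimated at 55000 nM in this assay, most likely between 15000 nM and 200000 nM.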

Compound 4, half-maximal inhibitory concentration: 78000 nM
Compound 4: the middle estimate sits 1.4-fold (0.15 log units) below what was measured; measured number inside the range.
By their numbers in this assay, from the lowest: compounds 2, 1 and 4 (each within the scatter of the next). At a limit, above all of these: compound 3.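

Among these compounds, this is the first measured step on the sulfonyl sulfur, and in this assay it reads a 1.2-fold higher number from compound 1 to compound 4 (0.09 log units; within the scatter). A six-membered aromatic ring of carbon only, with its added hydrogen-bond donor, can therefore stand in place of thiophen-2-yl without a change that the assay can resolve. Compound 3 gives a limit rather than a number: the limit of > 100000 nM in this assay, at which 1 of the 4 values shown sits.

As far as these compounds go, it remains open whether an amine or a carboxylic acid in place of the hydroxyl of 4-hydroxyphenyl would move the number beyond the scatter. The same holds for a simple methyl group on the sulfonyl sulfur.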